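A methoxy group added to compound 2

This account rests on a few compounds, and the source may have more. Where it says the series, first, only, none or still open, it means among the compounds named here.

In a functional assay on KG-1 cells (Homo sapiens) for inhibition, read by MTT assay, with a stated time of 48 h (on this read-out lower numbers stand for stronger inhibition and higher numbers for weaker inhibition), compound 2 (`O=C(NO)c1ccc(Oc2no[n+]([O-])c2S(=O)(=O)c2ccccc2)cc1`) gives 1240 nM and compound 3 (`O=C(NO)c1cccc(Oc2no[n+]([O-])c2S(=O)(=O)c2ccccc2)c1`) gives 1860 nM so these two lie within the scatter of each other. Compound 2 stands well apart from compound 1 (`O=C(COCCOc1no[n+]([O-])c1S(=O)(=O)c1ccccc1)NO`) which gives 7400 nM and so carries a higher number, beyond the scatter. Compound 4 (`COc1cc(C(=O)NO)ccc1Oc1no[n+]([O-])c1S(=O)(=O)c1ccccc1`) is compound 2 with methoxy in place of hydrogen on an aromatic carbon. Within the data shown here, no measured pair shows what this change does. Only a modest shift is therefore expected, none beyond the scatter, and the estimated step is a 1.1-fold higher number from compound 2 to compound 4 (0.05 log units; within the scatter) in this assay for now. For compound 4 the estimated value is 1400 nM with an expected range from 550 nM to 3500 nM at this stage.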

Compound 4, half-maximal inhibitory concentration: 1650 nM
For compound 4 the middle estimate is 1.2-fold (0.07 log units) below the measured one; measured number inside the range.
By their numbers in this assay, from the lowest: compounds 2, 4 and 3 (each within the scatter of the next); then compound 1.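

In this assay, methoxy in place of hydrogen on this aromatic carbon, ortho to a large group and meta to a hydroxycarbamoyl group, gives a 1.3-fold higher number from compound 2 to compound 4 (0.12 log units; within the scatter), so the added group leaves the value within the usual scatter. The earlier compounds had shown nothing about a substituent at this carbon. Nothing available explains why the value holds here.

From the compounds shown here alone, it remains open whether an amine, a carboxylic acid or a longer chain at this same carbon would also leave the value within the scatter. Going by these compounds, how methoxy would behave on the other carbons of this ring also remains open.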